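The source may hold more compounds than are shown below. What is called first, only, known or untested is meant among the compounds shown, and "the series" means these compounds.

Measured compounds:

Compound 1, `OCCc1cc2nn(-c3ccccc3)cc2cn1`, in a functional assay on MCF7 cells (Homo sapiens) for inhibition, read by fluorescence, with a stated time of 72 h (a lower number here means a stronger inhibitor of growth, a higher number a weaker inhibitor of growth), gives > 100000 nM, which is a limit of the assay and not a number.

Compound 2, `Cn1cc2cnc(-c3ccccc3)cc2n1`, in this assay gives > 100000 nM, again a limit of the assay rather than a number.

Compound 2 therefore stands at the edge of what this assay can report, with no numerical value of its own. Within the data shown here, the same holds for compound 1, so that the whole picture so far is summed up by the limit of > 100000 nM in this assay, at which 2 of the 2 values shown sit, and no step between measured compounds can be drawn. Compound 3, `c1ccc(-c2cc3nn(-c4ccccc4)cc3cn2)cc1`, is not yet measured. It differs from compound 2 by phenyl in place of methyl on an aromatic nitrogen. Among the measured compounds shown here, with both measured compounds sitting at the limit, there is no measured step from which to read the effect of this change, and the expectation for compound 3 rests on the two limits alone. Compound 3 is expected to remain weak in this assay, with an estimated value of 120000 nM and a range from 30000 nM to 500000 nM. The expected step that the limit leaves unreadable from compound 2 to compound 3 is estimated as none beyond the scatter, and a further limit rather than a number is the most likely outcome.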

Compound 3, concentration for 50% growth inhibition: 4800 nM
For compound 3 the middle estimate is 25-fold (1.40 log units) above the measured one; measured number below the stated range.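

Phenyl in place of methyl on an aromatic nitrogen brings an at least 20-fold lower number from compound 2 to compound 3 (1.31 log units; beyond the scatter) in this assay, and phenyl in place of 2-hydroxyethyl on an aromatic carbon brings an at least 20-fold lower number from compound 1 to compound 3 (1.31 log units; beyond the scatter). Both places therefore matter to growth inhibition in these cells: of the three compounds, only compound 3 carries phenyl at both, and only compound 3 gives a number, while phenyl at just one of the two places, as in compound 1 and compound 2, does not. Each step starts from a limit, so it marks only the least size of the change, and the full size cannot be read: the limit of > 100000 nM in this assay, at which 2 of the 3 values shown sit.

The two steps cannot be ranked against each other, and the compounds shown do not tell whether phenyl itself is required at each place. Going by these compounds, it remains open whether a benzyl or cyclohexyl group on the aromatic nitrogen, or an amine or a carboxylic acid on either phenyl ring, would keep, strengthen or lose the growth inhibition seen with compound 3.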